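The source may report more compounds than this note shows. Statements on the series, on what has been measured and on what is new or still open speak of the compounds shown alone.

Measured compounds in a functional assay on BT-549 cells (Homo sapiens) for cytotoxicity, read by sulforhodamine B assay, with a stated time of 48 h, tested at 0.1 uM; a higher number here means a weaker effect of the compound at the concentration tested, a lower number a stronger effect:
compound 1, `COc1cc(-c2cc(/C=C/C(=O)c3ccc(Cl)c(Cl)c3)[nH]n2)cc(OC)c1OC`, gives 95%;
compound 2, `COc1ccc(C(=O)/C=C/c2cc(-c3cc(OC)c(OC)c(OC)c3)n[nH]2)cc1OC`, gives 90%;
compound 3, `COc1ccc(C(=O)/C=C/c2cc(-c3cc(OC)c(OC)c(OC)c3)n[nH]2)cc1`, gives 97%.

Compound 2 has the lowest of these three numbers, but the steps of a number 5 percentage points lower from compound 1 to compound 2 (within the scatter) and a number 7 percentage points higher from compound 2 to compound 3 (within the scatter) show that all three compounds sit together within the usual scatter, each showing only a weak effect at the concentration tested. Compound 4, `COc1cc(C(=O)/C=C/c2cc(-c3cc(OC)c(OC)c(OC)c3)n[nH]2)cc(OC)c1OC`, differs from compound 2 by methoxy in place of hydrogen on an aromatic carbon. Going by the values given here, the one measured step that bears directly on this change is the step from compound 2 to compound 3, which takes away a methoxy group at an aromatic carbon: a number 7 percentage points higher from compound 2 to compound 3 (within the scatter), within the scatter. The step of a number 2 percentage points higher from compound 1 to compound 3 (within the scatter) likewise shows that swapping the groups on this ring leaves the number where it was. Adding a methoxy group is therefore expected to give no step beyond the scatter, and the value of compound 4 is estimated as 93%, in the range 83% to 100%, a step of a number 3 percentage points higher from compound 2 to compound 4 (within the scatter).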

Compound 4, a percentage reported as activity, at one concentration (the size of the read-out at that concentration, not a potency): 105%
Beside the measured number, compound 4's estimate is 12 percentage points below it, and the stated range ends below it.
By their numbers in this assay, from the lowest: compounds 2, 1, 3 and 4 (each within the scatter of the next, the first and the last beyond it).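

Going by these compounds alone, on the ring of compound 2, this is the first single change to move the number beyond the scatter: in this assay, a methoxy group on the carbon ortho to a methoxy group and meta to a large group gives a number 15 percentage points higher from compound 2 to compound 4 (beyond the scatter), a modest shift towards a weaker effect. Taking a methoxy group away from this ring gave only a number 7 percentage points higher from compound 2 to compound 3 (within the scatter), so one methoxy more and one methoxy less do not count the same in this pair of steps. Nothing measured here explains the difference.

Going by these compounds, it remains open whether a hydroxyl group, an amine or a longer chain such as ethoxy on this carbon would shift the number as methoxy does. On these data alone, it is also open whether the step holds at other concentrations, since this read-out comes from a single one.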